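Dropping One Methyl from a Diaryl Ether Thiazolidinedione

A few compounds are considered here, and "the series" means these few. Any claim that something is new, unique, unknown or untested is made for them only; others in the source may bear on it.

Compound 1 `Cc1ccc(Oc2ccc(CC3SC(=O)NC3=O)cc2)cc1C`: 727 nM
Compound 2 `O=C1NC(=O)C(Cc2ccc(Sc3ccccc3)cc2)S1`: 5060 nM

The two measured compounds were tested in a functional assay for agonist activity at Free fatty acid receptor 1 (Homo sapiens), read by FLIPR, in the presence of a further agent that is not named here; on this read-out lower numbers stand for an effect already at smaller amounts and higher numbers for an effect only at larger amounts of compound. Compound 1 gives 727 nM, the lowest number of the two. Compound 2 gives 5060 nM, a higher number, and the gap between the two lies beyond the usual scatter of repeated measurements, so compound 1 stands as the more potent of the pair.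

Compound 3 `Cc1ccc(Oc2ccc(CC3SC(=O)NC3=O)cc2)cc1` has not yet been measured. It differs from compound 1 in one place: hydrogen in place of methyl on an aromatic carbon of a six-membered aromatic ring of carbon only, ortho to a methyl group and meta to a large group. Among the measured compounds shown here, no pair of measured compounds shows what such a single change does here, so the direction of the step is open. Because compound 1 already gives 727 nM, the expectation is a modest step, if any, and most likely one that stays within the scatter: the step from compound 1 to compound 3 is estimated as a 1.5-fold higher number from compound 1 to compound 3 (0.18 log units; within the scatter). Compound 3 is therefore expected to give about 1100 nM, within a range from 400 nM to 3000 nM.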

Compound 3, half-maximal effective concentration: 547 nM
For compound 3 the middle estimate is 2.0-fold (0.30 log units) above the measured one; the measured number falls inside the stated range.
By their numbers in this assay, from the lowest: compounds 3 and 1 (each within the scatter of the next); then compound 2.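

In this assay, among the compounds shown here, compound 1 and compound 3 form the first pair that differs in one place only, so the effect of a single change can now be read directly. Putting hydrogen in place of methyl on this aromatic carbon, ortho to a methyl group and meta to a large group, gives a 1.3-fold lower number from compound 1 to compound 3 (0.12 log units; within the scatter), so the two compounds cannot be told apart in this measurement and this one methyl is not needed to keep the number seen with compound 1. Nothing measured here explains why the change leaves the number within the scatter.

For the compounds shown here, the other methyl group on the ring of compound 3 has no step of its own, so what its replacement by hydrogen would do remains open. As far as these compounds go, what other groups would do at the carbon that now carries hydrogen, such as chlorine, methoxy, trifluoromethyl or an amine, also remains open, since a methyl-to-hydrogen step says nothing about groups of a different kind.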